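The source may report more compounds than this note shows. Statements on the series, on what has been measured and on what is new or still open speak of the compounds shown alone.

The compounds here share one core and differ in what sits on an amide-type nitrogen at the far end of the molecule. Compound 1 `CCOC(=O)CCCN(C(=O)/C(C)=C/c1ccc(C(=O)Oc2ccc(C(=N)N)cc2)cc1)C(C(=O)OCC)C(=O)OCC` and compound 3 `CCOC(=O)CCCN(C(=O)/C(C)=C/c1ccc(C(=O)Oc2ccc(C(=N)N)cc2)cc1)C(C(=O)O)C(=O)OCC` carry a branched chain there, while compound 2 `C/C(=C\c1ccc(C(=O)Oc2ccc(C(=N)N)cc2)cc1)C(=O)N(CC(=O)O)C1CCCCC1` carries a carboxymethyl together with a cyclohexyl. In an in vitro ADME assay on a cell-free system (plasma) for pharmacokinetics (a lower number here means that the compound disappears faster, a higher number that the compound lasts longer), compound 1 gives < 0.0167 h, which is a limit of the assay rather than a number (the limit of < 0.0167 h in this assay, at which 1 of the 3 values shown sits). Compound 3 gives 0.233 h. For the measured compounds named here, the only measured step, an at least 13-fold higher number from compound 1 to compound 3 (1.14 log units; beyond the scatter), changes an ester into an acid. Compound 2 gives > 1 h, again a limit and not a number (the limit of > 1 h in this assay, at which 1 of the 3 values shown sits). Compound 2 thus stands at the long-lasting end of what has been measured. Compound 4 `CCN(CC(=O)O)C(=O)/C(C)=C/c1ccc(C(=O)Oc2ccc(C(=N)N)cc2)cc1` differs from compound 2 by ethyl in place of cyclohexyl on an amide-type nitrogen. Going by the values given here, no measured step touches this kind of change, since the one step measured concerns an ester that both compound 2 and compound 4 already hold as the acid. The step from compound 2 to compound 4 is therefore expected to be a step that the limit leaves unreadable from compound 2 to compound 4, within the scatter. Compound 4 is estimated at 1.5 h, with a range from 0.5 h to 5 h.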

Compound 4, half-life: 1 h
The estimate for compound 4 lay 1.5-fold (0.18 log units) above the measured number; the range from low to high includes it.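

In this assay, for the compounds shown here, the first change at the group that sits with the carboxymethyl on the amide-type nitrogen gives a number no higher from compound 2 to compound 4 (the limit leaves the size open). With the carboxymethyl kept and the cyclohexyl ring replaced by ethyl, compound 4 gives 1 h, a measured number rather than a limit. Compound 2 remains a limit, so what the ring adds, if anything, cannot be read: the limit of > 1 h in this assay, at which 1 of the 4 values shown sits.

The compounds shown leave open how a phenyl ring or a chain carrying an amine would behave on this nitrogen in place of ethyl in this assay. They also leave open whether a longer chain ending in a carboxylic acid, such as carboxyethyl, would read the same as the carboxymethyl.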